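Sulfonamide series: chloro added to the methoxyphenyl ring

The compounds below may be only part of what the source reports. "The series", "measured", "known", "first", "only" and "open" are said of these compounds alone.

Compound 1 `O=S(=O)(Nc1ccc2oc(-c3ccccc3)nc2c1)c1ccc(Cl)cc1` in an assay on cells for inhibition of HSP60/HSP10 (Homo sapiens), with a stated time of 60 min (a higher number here means a weaker inhibitor, a lower number a stronger inhibitor), gives > 100000 nM, a limit of the assay.
Compound 2 `O=S(=O)(Nc1ccc2oc(-c3ccccc3)nc2c1)c1ccccc1Cl` in this assay gives > 100000 nM, a limit.
Compound 3 `COc1ccccc1S(=O)(=O)Nc1ccc2oc(-c3ccccc3)nc2c1` in this assay gives > 100000 nM, a limit.

Compound 3 therefore stands only at a limit, not at a number, and the two other values shown are limits as well. The steps a step that the two limits leave unreadable from compound 1 to compound 3 and a step that the two limits leave unreadable from compound 2 to compound 3, like a step that the two limits leave unreadable from compound 1 to compound 2, cannot be read for size because of the limit of > 100000 nM in this assay, at which 3 of the 3 values shown sit. Compound 4 `COc1ccc(Cl)cc1S(=O)(=O)Nc1ccc2oc(-c3ccccc3)nc2c1` differs from compound 3 by chloro in place of hydrogen on an aromatic carbon. Going by the values given here, no measured step touches this change, and none of the measured steps has a readable size. The expectation for compound 4 in this assay is accordingly a value near the same limit, that is a step that the limit leaves unreadable from compound 3 to compound 4, with no direction beyond the scatter. The estimate for compound 4 is 150000 nM, from 40000 nM to 500000 nM, and a limit rather than a number is the likelier report.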

Compound 4, half-maximal inhibitory concentration: > 100000 nM
Compound 4: no number, only a limit; the forecaster's own chance of this, stated with the estimate: 85%; the middle value lies beyond the limit too.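

Compound 4 stands at a limit, as do compound 1, compound 2 and compound 3, so none of the steps to compound 4 can be read for size: the limit of > 100000 nM in this assay, at which 4 of the 4 values shown sit. The compounds shown leave open whether any group on the sulfonyl sulfur gives a number rather than a limit in this assay.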